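The source may hold more compounds than are shown below. What is called first, only, known or untested is meant among the compounds shown, and "the series" means these compounds.

Measured compounds:
- Compound 1 `O=C(O)CCc1ccc(NCc2ccc(C(F)(F)F)cc2)cc1`: 133%
- Compound 2 `O=C(O)CCc1ccc(NCc2cc(C(F)(F)F)cnc2Cl)cc1`: 112%
- Compound 3 `O=C(O)CCc1ccc(NCc2cccnc2)cc1`: 4%

Of the compounds shown here, three have been tested in a functional assay on CHO cells for agonist activity at Free fatty acid receptor 1 (Homo sapiens), read by reporter gene assay; a higher number here means a larger maximal response, a lower number a smaller maximal response. All share the same core and differ only in the group attached to the amine. Compound 1 stands highest of the three. Compound 2 comes nearest to it, with a response that lies below compound 1 by more than the scatter of this assay. Compound 3 lies far below both, also beyond the scatter, so the group on the benzylic ring clearly matters for the maximal response.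

Compound 4 `CN(C)Cc1ccc(CNc2ccc(CCC(=O)O)cc2)cc1` has not yet been measured. It differs from compound 1 in one place: (dimethylamino)methyl in place of trifluoromethyl on an aromatic carbon.

Among the measured compounds shown here, no measured pair maps this exact change, so the direction can only be guessed. Because compound 3 gives 4% while compound 1 gives 133%, a change in this part of the molecule can swing the response widely. The step from compound 1 to compound 4 is expected to be downward, a number 73 percentage points lower from compound 1 to compound 4 (beyond the scatter), beyond the scatter. For compound 4 the estimated value in this assay is 60%, with a range from 10% to 120%.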

Compound 4, largest response reached (reported as percent of maximum), in percent of the reference or control that the assay uses: 12%
The estimate for compound 4 lay 48 percentage points above the measured number; the measured number falls inside the stated range.
By their numbers in this assay, from the lowest: compounds 3 and 4 (each within the scatter of the next); then compound 2; then compound 1.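

At this position, on an aromatic carbon para to a large group, replacing trifluoromethyl with (dimethylamino)methyl in this assay gives a number 121 percentage points lower from compound 1 to compound 4 (beyond the scatter) and leaves little of the maximal response. The two groups have the same number of heavy atoms and neither contains a ring, so matching that count does not preserve the response; the change instead swaps fluorine for nitrogen and adds a hydrogen-bond acceptor. Nothing available explains the loss.

The compounds shown do not separate the contribution of the nitrogen from that of the overall shape of the new group. A tert-butyl group, made only of carbon and hydrogen, or a methoxymethyl group, with oxygen in place of nitrogen, at the same carbon would test these two features separately.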